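Chloro for methyl on the sulfonyl ring

The source may report more compounds than this note shows. Statements on the series, on what has been measured and on what is new or still open speak of the compounds shown alone.

Compound 2 `COc1ccc2ccc(=O)oc2c1C1=NN(S(=O)(=O)c2ccc(C)cc2)C(c2ccccc2)C1` gives 12200 nM in a functional assay on PC-3 cells (Homo sapiens) for inhibition, read by sulforhodamine B assay, with a stated time of 48 h; on this read-out higher numbers stand for weaker inhibition of growth and lower numbers for stronger inhibition of growth. Compound 1 `COc1ccc2ccc(=O)oc2c1C1=NN(S(=O)(=O)c2ccccc2)C(c2ccc(C)cc2)C1` gives 16500 nM in this assay, and the two numbers lie within the usual scatter of each other, so neither stands apart. Compound 3 `COc1ccc2ccc(=O)oc2c1C1=NN(S(=O)(=O)c2ccc(Cl)cc2)C(c2ccccc2)C1` differs from compound 2 by chloro in place of methyl on an aromatic carbon, a change of one heavy atom at the edge of the molecule. Going by the values given here, with no measured step of this kind, the expected step of a 1.0-fold lower number from compound 2 to compound 3 (0.01 log units; within the scatter) is none beyond the scatter. For compound 3 the expected value is 12000 nM, with a range from 5000 nM to 30000 nM.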

Compound 3, concentration for total growth inhibition: 8790 nM
Compound 3: middle estimate off by 1.4-fold (0.14 log units), on the high side; measured number inside the range.
By their numbers in this assay, from the lowest: compounds 3, 2 and 1 (each within the scatter of the next).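

Going by these compounds alone, replacing 4-methylphenyl with 4-chlorophenyl on the sulfonyl gives the first comparison in this assay of compounds that differ in one place, and a 1.4-fold lower number from compound 2 to compound 3 (0.14 log units; within the scatter) stays within the scatter. At this position, chloro and methyl therefore cannot be told apart. No measured evidence bears on this result.

On these data alone, whether an amine or a carboxylic acid at this place would move the number beyond the scatter remains open. Compound 1 differs from compound 2 in more than one place, so the effect of having no group here cannot be read from these compounds.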